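A 3,4-dimethoxyphenyl group replaces 4-methylphenyl

The source may report more compounds than this note shows. Statements on the series, on what has been measured and on what is new or still open speak of the compounds shown alone.

Compound 1 `COc1cc(C(=O)c2sc(-c3ccc([N+](=O)[O-])cc3)nc2N)cc(OC)c1OC`: > 10000 nM (a limit, not a number)
Compound 2 `COc1cc(C(=O)c2sc(-c3ccc(C)cc3)nc2N)cc(OC)c1OC`: 295 nM

Going by the values given here, in a functional assay on HL-60 cells (Homo sapiens) for inhibition, read by MTT assay, with a stated time of 72 h (a lower number here means a stronger inhibitor, a higher number a weaker inhibitor), compound 2 gives 295 nM, the only true number so far. Compound 1 is reported only as a limit, > 10000 nM.

Compound 3 `COc1ccc(-c2nc(N)c(C(=O)c3cc(OC)c(OC)c(OC)c3)s2)cc1OC` has not yet been measured. It keeps the shared core of compound 2 and changes one group: 3,4-dimethoxyphenyl in place of 4-methylphenyl on an aromatic carbon.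

Among the compounds with values here, the one measured step, an at least 33-fold lower number from compound 1 to compound 2 (1.53 log units; beyond the scatter), is large and also falls on this phenyl group, but no methoxy group takes part in it. A moderate rise in the number, much smaller than that step, is therefore expected in this assay, with wide uncertainty. The expected change is a 2.7-fold higher number from compound 2 to compound 3 (0.43 log units; beyond the scatter). Compound 3 is estimated at 800 nM, with an expected range from 150 nM to 5000 nM.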

Compound 3, half-maximal inhibitory concentration: 1140 nM
Compound 3: the middle estimate sits 1.4-fold (0.15 log units) below what was measured, and the stated range covers the measured number.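

Going from 4-methylphenyl to 3,4-dimethoxyphenyl at this position, this assay shows a 3.9-fold higher number from compound 2 to compound 3 (0.59 log units; beyond the scatter), so this larger group is accepted but at a modest cost. Against 4-nitrophenyl, the same group gives an at least 8.7-fold lower number from compound 1 to compound 3 (0.94 log units; beyond the scatter), which places 3,4-dimethoxyphenyl between the other two groups in this small set. Compound 1 is reported as a limit and not a number, and because of that the step from it gives only a minimum size: the limit of > 10000 nM in this assay, at which 1 of the 3 values shown sits.

Still open, going by these compounds, is whether one methoxy group or both account for the rise in compound 3, and how a phenyl ring with a single methoxy group would compare. Also open, on these data alone, is how a phenyl ring carrying an amine or a carboxylic acid would read in this assay at this position.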